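The source may hold more compounds than are shown below. What is called first, only, known or untested is meant among the compounds shown, and "the series" means these compounds.

Of the compounds shown here, three of one family have been tested in an assay for inhibition of kynurenine 3-monooxygenase (Rattus norvegicus), tested at 10 uM; a lower number here means less inhibition, a higher number more inhibition at the concentration tested (going by the name of the read-out). Compound 1, `COC(=O)C(=N)/C=C(\O)c1cccc(Br)c1`, gives 0% in this assay. Compound 2, `COC(=O)C(=N)/C=C(\O)c1cccc(F)c1`, differs from compound 1 by fluoro in place of bromo on an aromatic carbon; in this assay compound 2 gives 0%. The step of no change at the digits printed from compound 1 to compound 2 (within the scatter). Compound 3, `COC(=O)C(=N)/C=C(\O)c1ccc(Br)cc1`, is built from the same atoms as compound 1, joined differently; how the two cores differ is not broken down here. In this assay compound 3 gives 0%, level with compound 1 and compound 2 within the scatter.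

Compound 4, `COC(=O)C(=N)/C=C(\O)c1ccc(F)cc1`, has not been measured. It differs from compound 3 by fluoro in place of bromo on an aromatic carbon. For the measured compounds named here, this is the same kind of change as the one from compound 1 to compound 2, but the place is not the same: there the change sits meta to a group of 9 heavy atoms, here para to a group of 9 heavy atoms. Because the earlier step of no change at the digits printed from compound 1 to compound 2 (within the scatter), and because compound 3 gives 0%, the step of no change at the digits printed from compound 3 to compound 4 (within the scatter) is expected to be small. Compound 4 is estimated to give 0% in this assay, between 0% and 10%.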

Compound 4, a percentage reported as inhibition, at one concentration (the size of the read-out at that concentration, not a potency): 1%
Compound 4: the middle estimate sits 1 percentage points below what was measured; the measured number falls inside the stated range.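

Putting fluoro in place of bromo on the core of compound 3 in this assay gives a number 1 percentage points higher from compound 3 to compound 4 (within the scatter). Set beside the same change on the core of compound 1, the result carries over without a difference that can be told from the scatter: the same change on two cores in this assay, no change at the digits printed (within the scatter) from compound 1 to compound 2 and a number 1 percentage points higher (within the scatter) from compound 3 to compound 4, 1 percentage points apart, within the scatter of two such steps. This does not show that the change is harmless or unimportant in general: all four compounds sit at the very bottom of the read-out, with hardly any inhibition to lose, so the two steps say nothing about how the same change would behave on a compound that clearly inhibits the enzyme.

All four compounds keep the methyl ester and carry a single halogen on the aromatic ring, which leaves open whether a carboxylic acid in place of that ester would lift the read-out off the floor. The same question stands for an amine or a methoxy group on the ring in place of the halogen.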